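This account rests on a few compounds, and the source may have more. Where it says the series, first, only, none or still open, it means among the compounds named here.

Among the compounds with values here, compound 2 `CCCn1c(=O)c2nc(C(C3CC3)C3CC3)[nH]c2n(CCC)c1=O` holds the lowest of the two numbers so far in an assay on cell membranes for binding affinity to adenosine receptor A1 (Cavia porcellus) (a lower number here means a stronger inhibitor, a higher number a weaker inhibitor), giving 3 nM; its nearest neighbour is compound 1 `CCCn1c(=O)c2nc(C(CC)CC)[nH]c2n(CCC)c1=O`, which in this assay gives 19 nM, with the step of a 6.3-fold lower number from compound 1 to compound 2 (0.80 log units; beyond the scatter) marking the gap between them. Compound 3 `CCCn1c(=O)c2nc(C(c3ccc(OC)cc3)C3CC3)[nH]c2n(CCC)c1=O` departs from compound 2 by a single change: 4-methoxyphenyl in place of cyclopropyl on a saturated chain carbon bound to an aromatic carbon and a saturated ring carbon. Within the data shown here, the one measured step, from compound 1 to compound 2, concerned an exchange of two saturated branches on the same carbon and was modest in size; no measured pair shows an aromatic ring entering at this place, so that step offers only weak guidance. A small weakening is expected for compound 3 from this change, a 3.3-fold higher number from compound 2 to compound 3 (0.52 log units; beyond the scatter), the entering six-membered aromatic ring with its one acceptor being a larger departure than any change measured here. Compound 3 is therefore estimated in this assay at 10 nM, within 2 nM to 60 nM.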

Compound 3, inhibition constant: 250 nM
Estimate against measurement, compound 3: 25-fold (1.40 log units) below; measured number outside the range, above it.
By their numbers in this assay, from the lowest: compound 2; then compound 1; then compound 3.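

Putting 4-methoxyphenyl in place of cyclopropyl on this saturated chain carbon gives an 83-fold higher number from compound 2 to compound 3 (1.92 log units; beyond the scatter) in this assay, a large step that runs opposite in direction to the modest 6.3-fold lower number from compound 1 to compound 2 (0.80 log units; beyond the scatter) between saturated branches. Within the data shown here, this is the first pair in which an aromatic ring enters at this place, and it shows that this carbon does not accept every exchange of one branch for another with a similar result. Nothing available explains the size of this step.

The compounds shown cannot separate the contribution of the phenyl ring from that of its methoxy group, as plain phenyl is not among them. They also leave open how a 4-hydroxyphenyl or 4-fluorophenyl group, or a cyclobutyl ring, would fare at this place.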